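This account rests on a few compounds, and the source may have more. Where it says the series, first, only, none or still open, it means among the compounds named here.

Measured so far in an ADME assay on HEK293 cells (Homo sapiens) for cytotoxicity, read by resazurin assay, with a stated time of 48 h; a lower number here means that less compound is tolerated, a higher number that more compound is tolerated:
compound 1 `O=S(=O)(Nc1ccc(-c2nc3ccccc3o2)cc1)c1ccc(F)c(C(F)(F)F)c1`: 82000 nM
compound 2 `Cc1ccccc1S(=O)(=O)Nc1ccc2oc(-c3ccccc3)nc2c1`: 57000 nM
compound 3 `O=S(=O)(Nc1ccc(-c2nc3ccccc3o2)cc1)c1ccc(F)cc1`: > 100000 nM, a limit of the assay

Compound 2 gives the lowest of the two numbers; the nearest, compound 1, lies within the scatter of it. Compound 3 shows only a limit of the assay, (the limit of > 100000 nM in this assay, at which 1 of the 3 values shown sits). For the measured compounds named here, the one step measured so far, an at least 1.2-fold higher number from compound 1 to compound 3 (0.08 log units; that floor lies within the scatter), concerns a different change, and its floor lies within the scatter.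

Compound 4 `COc1ccccc1S(=O)(=O)Nc1ccc2oc(-c3ccccc3)nc2c1` differs from compound 2 in one place: methoxy in place of methyl on an aromatic carbon. Going by the values given here, no measured step covers methoxy in place of methyl, so in this assay no step beyond the scatter is expected: a 1.1-fold higher number from compound 2 to compound 4 (0.02 log units; within the scatter). Compound 4 is estimated at 60000 nM, between 25000 nM and 150000 nM.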

Compound 4, half-maximal cytotoxic concentration: 41000 nM
Compound 4: middle estimate off by 1.5-fold (0.17 log units), on the high side, within the range that was stated.
By their numbers in this assay, from the lowest: compounds 4, 2 and 1 (each within the scatter of the next). At a limit, above all of these: compound 3.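

Methoxy in place of methyl on an aromatic carbon, ortho to a large group, is the first change read at this position: a 1.4-fold lower number from compound 2 to compound 4 (0.14 log units; within the scatter). In this assay the 2-methylphenyl and 2-methoxyphenyl groups cannot be told apart, so this position takes the added oxygen with no step beyond the scatter. No available evidence bears on this step.

Open, as far as these compounds go, is how an amine or a carboxylic acid at this position would read in this assay. Also open, from the compounds shown here alone, is whether a longer chain such as ethoxy would stay within the scatter of compound 2.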